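The source may report more compounds than this note shows. Statements on the series, on what has been measured and on what is new or still open speak of the compounds shown alone.

Working notes on the sulfonamide series.

Compound 1 `NS(=O)(=O)c1ccc(N/C=C\C(=O)c2cc3ccccc3oc2=O)cc1` is the parent with an unsubstituted sulfonamide nitrogen. In a functional assay on T47D cells (Homo sapiens) for cytotoxicity, read by sulforhodamine B assay, with a stated time of 48 h (a lower number here means a stronger inhibitor, a higher number a weaker inhibitor), compound 1 gives 109000 nM. Compound 2 `N=C(N)NS(=O)(=O)c1ccc(N/C=C\C(=O)c2cc3ccccc3oc2=O)cc1` gives 87600 nM in this assay, and compound 3 `Cc1noc(NS(=O)(=O)c2ccc(N/C=C\C(=O)c3cc4ccccc4oc3=O)cc2)c1C` gives 68400 nM. Compound 3 holds the lowest number of the three, but its gaps to compound 2 and compound 1 are both within the scatter, so no ordering among them is supported. The measured steps are all small: a 1.2-fold lower number from compound 1 to compound 2 (0.09 log units; within the scatter), a 1.6-fold lower number from compound 1 to compound 3 (0.20 log units; within the scatter) and a 1.3-fold lower number from compound 2 to compound 3 (0.11 log units; within the scatter).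

Compound 4 `O=C(/C=C\Nc1ccc(S(=O)(=O)Nc2cnc3ccccc3n2)cc1)c1cc2ccccc2oc1=O` is not yet measured in this assay. Against compound 3 the change is quinoxalin-2-yl in place of 3,4-dimethyl-1,2-oxazol-5-yl on a sulfonamide nitrogen. The step from compound 2 to compound 3, which swapped one group for a ring on the same sulfonamide nitrogen, bears most directly on it and stayed within the scatter, as did the step from compound 1 to compound 3. A step within the scatter, in either direction, is therefore expected here. The estimated value for compound 4 in this assay is 60000 nM, with a range from 25000 nM to 150000 nM. The expected step is a 1.1-fold lower number from compound 3 to compound 4 (0.06 log units; within the scatter).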

Compound 4, half-maximal inhibitory concentration: 86900 nM
For compound 4 the middle estimate is 1.4-fold (0.16 log units) below the measured one; measured number inside the range.
By their numbers in this assay, from the lowest: compounds 3, 4, 2 and 1 (each within the scatter of the next).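

On the sulfonamide nitrogen, quinoxalin-2-yl adds a group with two six-membered aromatic rings, and the number stays within the scatter against each earlier compound: a 1.3-fold higher number from compound 3 to compound 4 (0.10 log units; within the scatter), a 1.0-fold lower number from compound 2 to compound 4 (0.00 log units; within the scatter) and a 1.3-fold lower number from compound 1 to compound 4 (0.10 log units; within the scatter). In this assay all four compounds now lie within the scatter of one another, so from hydrogen up to quinoxalin-2-yl, the size of the group at this place shows no readable link to the number. No measurement at hand offers an explanation for this flat result.

Open, as far as these compounds go, is whether a group of another kind on this nitrogen, such as a longer alkyl chain or a carboxylic acid, would give a step beyond the scatter. Also open, from the compounds shown here alone, is whether a change elsewhere on the shared core would do so.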